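Ethyl for fluoro on the fused carbocycle: working notes

This account rests on a few compounds, and the source may have more. Where it says the series, first, only, none or still open, it means among the compounds named here.

Measured in a functional assay on the whole organism (strain Sprague-Dawley) for inhibition, with Rattus norvegicus as the target; a lower number here means that less compound is needed, a higher number that more compound is needed for the effect:
compound 1 `CCc1cccc2c(=O)c(-c3nn[nH]n3)c[nH]c12`: > 25 mg/kg, a limit of the assay
compound 2 `O=c1c(-c2nn[nH]n2)c[nH]c2c(F)cccc12`: 10 mg/kg
compound 3 `O=c1c(-c2nn[nH]n2)c[nH]c2ccc(F)cc12`: > 20 mg/kg, a limit of the assay

Compound 2 and compound 1 share a core and differ only where (ethyl in place of fluoro on an aromatic carbon). In this assay that change gave an at least 2.5-fold higher number from compound 2 to compound 1 (0.39 log units; beyond the scatter). On these data alone, the value of compound 1 sits at the limit of > 25 mg/kg in this assay, at which 1 of the 3 values shown sits, so the true size of the step is unknown and only its lower bound is known.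

Compound 3 has the same atoms as compound 2, joined differently; the difference between the two cores is not broken down here. Compound 3 sits at the limit of > 20 mg/kg in this assay, at which 1 of the 3 values shown sits.

Compound 4 `CCc1ccc2[nH]cc(-c3nn[nH]n3)c(=O)c2c1` is not yet measured. Relative to compound 3 it carries ethyl in place of fluoro on an aromatic carbon. Among the measured compounds shown here, this is the same kind of change as the one from compound 2 to compound 1, but the surroundings differ: in compound 1 the ethyl sits ortho to a fused ring and meta to a fused ring, whereas in compound 4 it sits meta to a fused ring and para to a fused ring.

In this assay compound 4 is expected to give a step that the limit leaves unreadable from compound 3 to compound 4, because the same kind of change gave an at least 2.5-fold higher number from compound 2 to compound 1 (0.39 log units; beyond the scatter) and compound 3 already sits at a limit. The estimate for compound 4 is 40 mg/kg, with a range from 15 mg/kg to 120 mg/kg, and the assay will most likely again report only a limit.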

Compound 4, minimum effective dose: 0.625 mg/kg
Compound 4: middle estimate off by 64-fold (1.81 log units), on the high side; measured number outside the range, below it.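

In this assay, ethyl in place of fluoro gave an at least 32-fold lower number from compound 3 to compound 4 (1.50 log units; beyond the scatter), so the change does not carry over from one core to the other with the same direction, and the outcome of this swap in the series has to be read core by core: the same change on two cores in this assay, an at least 2.5-fold higher number (0.39 log units; beyond the scatter) from compound 2 to compound 1 and an at least 32-fold lower number (1.50 log units; beyond the scatter) from compound 3 to compound 4, at least 80-fold (1.90 log units) apart, beyond the scatter of two such steps

On these data alone, compound 3 stands at a limit of the assay, > 20 mg/kg, so the true size of the new step is unknown and only its lower bound can be read.

Compound 1 also stands at a limit of the assay, > 25 mg/kg, and the two cores differ in where the change sits, with the ethyl of compound 4 meta to a fused ring and para to a fused ring, so the pair of steps shows that the result depends on the core but does not show what in the core decides it.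

The compounds shown hold only fluoro and ethyl at this place on the core of compound 4, and it remains open whether a methyl group, a longer chain such as propyl, or a methoxy group there would give a number like that of compound 4. As far as these compounds go, it also remains open how the unsubstituted core would stand against compound 3 and compound 4 in this assay.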